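A few compounds are considered here, and "the series" means these few. Any claim that something is new, unique, unknown or untested is made for them only; others in the source may bear on it.

Compound 1 `COc1c(N2C[C@H]3CCCN(C(=O)Cn4cc(CN5C(=O)C(=O)c6ccccc65)nn4)[C@H]3C2)c(F)cc2c(=O)c(C(=O)O)cn(C3CC3)c12`: 32 ug/mL
Compound 2 `COc1c(N2C[C@H]3CCCN(C(=O)Cn4cc(CN5C(=O)C(=O)c6cccc(F)c65)nn4)[C@H]3C2)c(F)cc2c(=O)c(C(=O)O)cn(C3CC3)c12`: 32 ug/mL
Compound 3 `CO/N=C1/C(=O)N(Cc2cn(CC(=O)N3CCC[C@@H]4CN(c5c(F)cc6c(=O)c(C(=O)O)cn(C7CC7)c6c5OC)C[C@@H]43)nn2)c2ccccc21`: 128 ug/mL

Of the compounds shown here, three have been measured in an ADME assay on Vero cells (Chlorocebus sabaeus) for cytotoxicity, read by MTT assay, with a stated time of 72 h; a higher number here means that more compound is tolerated, a lower number that less compound is tolerated. Compound 1 gives 32 ug/mL and compound 2 gives 32 ug/mL; the two differ by fluoro in place of hydrogen on an aromatic carbon, and the step of no change at the digits printed from compound 1 to compound 2 (within the scatter). Compound 3 gives 128 ug/mL, the highest of the three numbers, and the difference between its core and the core of compound 1 is not broken down here.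

Compound 4 `CO/N=C1/C(=O)N(Cc2cn(CC(=O)N3CCC[C@@H]4CN(c5c(F)cc6c(=O)c(C(=O)O)cn(C7CC7)c6c5OC)C[C@@H]43)nn2)c2c(F)cccc21` has not yet been measured in this assay. It differs from compound 3 by fluoro in place of hydrogen on an aromatic carbon, the same change as that from compound 1 to compound 2, which occurs twice among these compounds. The earlier occurrence left the number unchanged within the scatter, and the expectation for compound 4 rests on that step no change at the digits printed from compound 1 to compound 2 (within the scatter) together with the value of compound 3. Compound 4 is therefore expected to give 128 ug/mL. For compound 4 the expected range runs from 64 ug/mL to 256 ug/mL. The expected step is no change at the digits printed from compound 3 to compound 4 (within the scatter).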

Compound 4, half-maximal cytotoxic concentration: 16 ug/mL
Compound 4: the middle estimate sits 8.0-fold (0.90 log units) above what was measured, outside the stated range (below it).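

In this assay, fluoro in place of hydrogen on an aromatic carbon gives an 8.0-fold lower number from compound 3 to compound 4 (0.90 log units; beyond the scatter), so the change tolerated on the core of compound 1 does not behave in the same way on the core of compound 3. Among these compounds, the outcome of this change therefore did not carry from one core to the other: the same change on two cores in this assay, no change at the digits printed (within the scatter) from compound 1 to compound 2 and an 8.0-fold lower number (0.90 log units; beyond the scatter) from compound 3 to compound 4, 8.0-fold (0.90 log units) apart, beyond the scatter of two such steps This shows that the step seen on one core cannot be taken as a guide to the other, but with only one matched pair on each core it does not show which structural difference between the cores matters, or why the outcomes differ.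

The compounds shown leave open whether chloro or methyl on the same aromatic carbon would follow the fluoro step on either core. They also leave open whether a methoxy group there would separate the two cores in the same way.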